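The source may report more compounds than this note shows. Statements on the series, on what has been measured and on what is new or still open speak of the compounds shown alone.

Compound 1 `O=S(=O)(c1ccc(F)c(F)c1)c1cnc2cc(F)ccc2c1-c1ccc(Cl)cc1` is the starting point of this comparison. In an ADME assay on microsomes from liver (Homo sapiens) for metabolic stability, tested at 2.5 uM (a lower number here means slower removal, a higher number faster removal of the compound), compound 1 gives 0.01 mL/min, the lowest number among the three compounds measured here. Compound 2 `O=S(=O)(c1cc(Cl)cc(Cl)c1)c1cnc2c(F)cccc2c1-c1ccccc1F` gives 0.44 mL/min in this assay, and compound 3 `O=S(=O)(c1ccc(F)cc1)c1cnc2cc(F)ccc2c1-c1ccc(Cl)cc1` gives 1.23 mL/min. Among the measured compounds shown here, the only change between two measured compounds that differs in a single place runs a 120-fold higher number from compound 1 to compound 3 (2.09 log units; beyond the scatter), so exchanging one fluoro for hydrogen on an aromatic carbon moved the number a long way upward.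

Compound 4 `O=S(=O)(c1ccc(F)c(F)c1)c1cnc2cc(F)ccc2c1-c1cccc(F)c1` differs from compound 1 by 3-fluorophenyl in place of 4-chlorophenyl on an aromatic carbon. For the measured compounds named here, no measured step touches this part of compound 1; the change from compound 1 to compound 3 sits on a different aromatic ring, so it offers only a general warning that a single swap on an aromatic ring can shift the number in this assay far beyond the usual scatter. Since compound 1 holds the lowest value and both other compounds lie well above it, a step from compound 1 to compound 4 seems more likely to go upward than downward, but its size cannot be read from the data. I estimate that compound 4 will give 0.06 mL/min, within a range from 0.01 mL/min to 0.5 mL/min. The expected step is therefore a 6.0-fold higher number from compound 1 to compound 4 (0.78 log units; beyond the scatter).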

Compound 4, intrinsic clearance in a liver preparation (reported as CLH), per the amount of preparation that the assay uses: 0.6 mL/min
Compound 4: middle estimate off by 10-fold (1.00 log units), on the low side, outside the stated range (above it).
By their numbers in this assay, from the lowest: compound 1; then compounds 2 and 4 (each within the scatter of the next); then compound 3.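

In this assay the position opposite the ring nitrogen proves highly sensitive: 3-fluorophenyl in place of 4-chlorophenyl gives a 60-fold higher number from compound 1 to compound 4 (1.78 log units; beyond the scatter) even though the two groups match in their counts of heavy atoms, donors and acceptors and differ only in the halogen and where it sits on the ring. Set beside a 120-fold higher number from compound 1 to compound 3 (2.09 log units; beyond the scatter) on a different aromatic ring, this shows that a single change at either of two separate places is enough to lose the very low number of compound 1, so that number does not depend on one part of the molecule alone. Nothing available here gives a reason for the rise at this position.

This one step changes the halogen and its place on the ring together, so it cannot say which of the two carries the rise, and 4-fluorophenyl or 3-chlorophenyl at this position would separate them. Also open, on these data alone, are how the number would respond to plain phenyl or to a phenyl ring bearing an amine or a methoxy group here, and whether the step keeps its size on the core of compound 3.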